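The source may report more compounds than this note shows. Statements on the series, on what has been measured and on what is new or still open speak of the compounds shown alone.

Of the compounds shown here, three of one shared core have been measured in an assay on isolated protein (Oryctolagus cuniculus) with Thromboxane-A synthase (Homo sapiens) as the target, tested at 1 uM; on this read-out lower numbers stand for less inhibition and higher numbers for more inhibition at the one concentration tested (going by the name of the read-out). Compound 1, `CCCCn1nc(-c2cccnc2)c2ccccc2c1=O`, gives 91%. Compound 2, `CCCCCCCCn1nc(-c2cccnc2)c2ccccc2c1=O`, gives 99%. Compound 3, `O=c1c2ccccc2c(-c2cccnc2)nn1CC1CCCCC1`, gives 98%. On these numbers compound 3 stands closest to compound 2, the step being a number 1 percentage points lower from compound 2 to compound 3 (within the scatter), and the step of a number 7 percentage points higher from compound 1 to compound 3 (within the scatter) is likewise within the scatter, so all three sit together at high inhibition.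

Compound 4, `O=c1c2ccccc2c(-c2cccnc2)nn1Cc1ccccc1`, differs from compound 3 in one place: phenyl in place of cyclohexyl on a saturated chain carbon bound to an aromatic nitrogen. Going by the values given here, the steps that bear on this change are those at the same place, namely a number 7 percentage points higher from compound 1 to compound 3 (within the scatter) and a number 1 percentage points lower from compound 2 to compound 3 (within the scatter), where propyl and heptyl were each exchanged for cyclohexyl and the read-out did not move beyond the scatter. Varying the group on the saturated chain carbon bound to the aromatic nitrogen has so far left the read-out at a high level, so no step beyond the scatter is expected for a number 2 percentage points lower from compound 3 to compound 4 (within the scatter). For compound 4 the expected value is 96%, with a range from 86% to 100%.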

Compound 4, a percentage reported as inhibition, at one concentration (the size of the read-out at that concentration, not a potency): 97%
For compound 4 the middle estimate is 1 percentage points below the measured one; low and high end bracket the measured number.
By their numbers in this assay, from the lowest: compounds 1, 4, 3 and 2 (each within the scatter of the next).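

In this assay, phenyl in place of cyclohexyl gives a number 1 percentage points lower from compound 3 to compound 4 (within the scatter) and so shows that an aromatic ring on this saturated chain carbon cannot be told apart from a non-aromatic ring of the same size. The open chains compare in the same way, with a number 2 percentage points lower from compound 2 to compound 4 (within the scatter) for phenyl in place of heptyl and a number 6 percentage points higher from compound 1 to compound 4 (within the scatter) for phenyl in place of propyl, so aromatic ring, non-aromatic ring and chains all lie within the scatter of one another at this place. Nothing measured on these compounds speaks to why the read-out holds here.

Going by these compounds, whether an amine or a carboxylic acid at this place would keep the inhibition this high remains open, as does the effect of a bare hydrogen in place of the whole group. On these data alone, with a single tested concentration and all four compounds at high inhibition, any differences in potency among them also remain open.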